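Aryl change on the triazole nitrogen: compound 4

The source may hold more compounds than are shown below. What is called first, only, known or untested is meant among the compounds shown, and "the series" means these compounds.

The series shares one core across three measured compounds. Compound 1 `C/C(=C\CC/C(C)=C/CC[C@@H]1[C@@]2(C)CCC(=O)C(C)(C)[C@H]2CC[C@@]1(C)O)CC/C=C(\C)C(=O)OCc1cn(-c2ccccc2C(F)(F)F)nn1` reports in a functional assay on DU-145 cells (Homo sapiens) for antiproliferative activity, read by MTT assay, with a stated time of 48 h (on this read-out higher numbers stand for weaker inhibition and lower numbers for stronger inhibition), only a limit, > 150000 nM. Compound 2 `C/C(=C\CC/C(C)=C/CC[C@@H]1[C@@]2(C)CCC(=O)C(C)(C)[C@H]2CC[C@@]1(C)O)CC/C=C(\C)C(=O)OCc1cn(C[C@@H]2O[C@H](n3ccc(=O)[nH]c3=O)[C@H]3OC(C)(C)O[C@H]32)nn1` likewise gives only a limit in this assay, > 150000 nM. Among the measured compounds shown here, compound 3 `C/C(=C\CC/C(C)=C/CC[C@@H]1[C@@]2(C)CCC(=O)C(C)(C)[C@H]2CC[C@@]1(C)O)CC/C=C(\C)C(=O)OCc1cn(-c2cccc(Cl)c2)nn1` is the single compound with a number, 103000 nM in this assay. It therefore stands as the only measured point beside (the limit of > 150000 nM in this assay, at which 2 of the 3 values shown sit). For the measured compounds named here, the one directional step, an at least 1.4-fold lower number from compound 1 to compound 3 (0.16 log units; that floor lies within the scatter), rests on a limit and stays within the scatter. Going by the values given here, compound 4 `C/C(=C\CC/C(C)=C/CC[C@@H]1[C@@]2(C)CCC(=O)C(C)(C)[C@H]2CC[C@@]1(C)O)CC/C=C(\C)C(=O)OCc1cn(-c2ccc(C)cc2)nn1` carries 4-methylphenyl in place of 3-chlorophenyl on an aromatic nitrogen; no measured step tests a methyl against a chlorine on this ring, so the step of a 1.2-fold higher number from compound 3 to compound 4 (0.07 log units; within the scatter) is expected to lie within the scatter. Compound 4 is therefore estimated at 120000 nM, range 50000 nM to 300000 nM, with a fair chance that only a limit is returned.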

Compound 4, half-maximal inhibitory concentration: > 150000 nM
Compound 4 ended at the assay's limit; the forecaster's own chance of this, stated with the estimate: 40%; at least 1.2-fold (0.09 log units) between middle value and limit.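

With 4-methylphenyl on the aromatic nitrogen, this assay gives an at least 1.4-fold higher number from compound 3 to compound 4 (0.16 log units; that floor lies within the scatter), so this aryl change has not produced a separation beyond the scatter at this position. The steps between compound 1 and compound 4 cannot be read, as both values are limits. Compound 3 remains the only compound with a number, and the series gathers at one value: the limit of > 150000 nM in this assay, at which 3 of the 4 values shown sit.

Going by these compounds, whether an amine or a carboxylic acid on the phenyl ring would give a number clearly under this limit remains open. On these data alone, whether any aryl group on this nitrogen can separate from the limit also remains open.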